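A few compounds are considered here, and "the series" means these few. Any claim that something is new, unique, unknown or untested is made for them only; others in the source may bear on it.

Measured in a functional assay on HCT-15 cells (Homo sapiens) for cytotoxicity, in the presence of a further agent that is not named here; a lower number here means a stronger inhibitor, a higher number a weaker inhibitor:
- compound 1 `Cc1cccc(-c2cc(-c3ccc(Cl)o3)cc(-c3ccsc3)n2)c1` gives 21700 nM
- compound 2 `Cc1ccc(-c2cc(-c3ccoc3)cc(-c3ccsc3)n2)cc1` gives 44800 nM
- compound 3 `Clc1ccc(-c2cc(-c3ccoc3)cc(-c3cccs3)n2)cc1` gives 50000 nM

Compound 1 has the lowest of these three numbers, and the gap to each of the others lies beyond the scatter, so it is the strongest inhibitor of the three. Compound 4 `Clc1ccc(-c2cc(-c3cccnc3)nc(-c3ccsc3)c2)o1` keeps the core of compound 1 but carries pyridin-3-yl in place of 3-methylphenyl on an aromatic carbon. Going by the values given here, no measured pair shows this change directly. Among the compounds with values here, the only guide is the narrow spread of values, from compound 1 at 21700 nM to compound 3 at 50000 nM, so no change beyond the scatter is expected in this assay. The expected step is a 1.4-fold higher number from compound 1 to compound 4 (0.14 log units; within the scatter). For compound 4 the estimated value is 30000 nM, with an expected range of 12000 nM to 60000 nM.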

Compound 4, half-maximal inhibitory concentration: > 50000 nM
Compound 4 ended at the assay's limit; the forecaster's own chance of this, stated with the estimate: 25%; middle value at least 1.6-fold (0.22 log units) away from the limit.
By their numbers in this assay, from the lowest: compound 1; then compounds 2 and 3 (each within the scatter of the next).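

In this assay, pyridin-3-yl in place of 3-methylphenyl, on the aromatic carbon next to the ring nitrogen, gives an at least 2.3-fold higher number from compound 1 to compound 4 (0.36 log units; beyond the scatter), so compound 4 is a weaker inhibitor. Going by these compounds alone, this is the first direct reading of a single change, as no earlier pair differed in only one place. For compound 4, > 50000 nM is a limit of the assay and not a number: the limit of > 50000 nM in this assay, at which 1 of the 4 values shown sits.

The compounds shown leave open whether the ring nitrogen or the missing methyl accounts for this step. Plain phenyl at this position, or a ring carrying an amine or a carboxylic acid, remains unplaced.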